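This account rests on a few compounds, and the source may have more. Where it says the series, first, only, none or still open, it means among the compounds named here.

Compound 1 `Cc1cn([C@@H]2CC(F)(F)[C@H](CO)O2)c(=O)nc1O` carries a methyl on its core, and compound 2 `O=c1nc(O)ccn1[C@@H]1CC(F)(F)[C@H](CO)O1` is its counterpart with hydrogen in place of methyl on an aromatic carbon. In a functional assay on CCRF-CEM cells (Homo sapiens) for cytotoxicity (a higher number here means a weaker inhibitor, a lower number a stronger inhibitor), compound 1 gives only a limit, > 100000 nM. Compound 2 likewise gives only a limit in this assay, > 100000 nM. The step that the two limits leave unreadable from compound 1 to compound 2 is thus not readable, since both values sit at the limit of > 100000 nM in this assay, at which 3 of the 3 values shown sit. Compound 3 `Cc1cn([C@@H]2C=C(F)[C@H](CO)O2)c(=O)nc1O` rests on a second core; how it differs from compound 1 is not broken down here. In this assay compound 3 also gives only a limit, > 100000 nM. Compound 4 `O=c1nc(O)ccn1[C@@H]1C=C(F)[C@H](CO)O1` stands to compound 3 as compound 2 stands to compound 1, the same kind of change (hydrogen in place of methyl on an aromatic carbon), the surroundings differing only in that the group meta to the place has 8 heavy atoms rather than 9. Among the measured compounds shown here, with every value so far resting at a limit, the step that the limit leaves unreadable from compound 3 to compound 4 is expected to remain unreadable. Compound 4 is therefore estimated at 150000 nM, most likely reported again only as a limit.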

Compound 4, half-maximal inhibitory concentration: 30100 nM
Estimate against measurement, compound 4: 5.0-fold (0.70 log units) above, and the stated range ends above it.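

In this assay, hydrogen in place of methyl on an aromatic carbon gives an at least 3.3-fold lower number from compound 3 to compound 4 (0.52 log units; beyond the scatter), so on the core of compound 3 the change lowers the number beyond the scatter. On the core of compound 1 the same change cannot be read, since the steps there rest on limits at both ends: the limit of > 100000 nM in this assay, at which 3 of the 4 values shown sit. The series therefore shows the change acting on one core only; it does not show that the effect carries over to the other core, and the size of the step is itself only a bound, as compound 3 gives a limit. The compounds shown leave open whether an ethyl group, a bromine or an amine on that aromatic carbon would lower the number further on either core.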